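The source may report more compounds than this note shows. Statements on the series, on what has been measured and on what is new or still open speak of the compounds shown alone.

Working notes on three measured compounds and one pending compound, all read in a functional assay on the whole organism for antagonist activity, with Mus musculus as the target; on this read-out lower numbers stand for an effect already at smaller amounts and higher numbers for an effect only at larger amounts of compound. For the measured compounds named here, compound 1 `CC(C#CCn1ccnc1)N1CCCC1=O` gives 2 mg/kg, the only value in the set that is an actual number. Compound 2 `COC(=O)N(C)C(C)C#CCN(C)C` gives > 100 mg/kg, and this value is a limit of the assay. Compound 3 `Cn1ccn(CC#CCN2CCCC2)c1=O` gives > 10 mg/kg, which is also a limit of the assay. Going by the values given here, compound 3 therefore has no exact position on the numbers so far, and it stands with compound 2 as one of the two limit readings.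

Compound 4 `CN(C)CC#CCn1ccn(C)c1=O` has not yet been measured. It differs from compound 3 by a single change, dimethylamino in place of pyrrolidin-1-yl on a saturated chain carbon bound to a triple-bonded carbon.

Among the compounds with values here, no measured pair in the set differs in one place, so the data give no step size for this change. In this assay, the expectation for this change is no step beyond the usual scatter, and the expected step that the limit leaves unreadable from compound 3 to compound 4 is small. This expectation rests on compound 3 and its limit of > 10 mg/kg. Another limit reading is expected to be a likely outcome for compound 4. The estimate for compound 4 is 20 mg/kg, with an expected range from 6 mg/kg to 100 mg/kg.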

Compound 4, dose for half-maximal effect: > 100 mg/kg
Compound 4 gave a limit, no number (the forecaster's own chance of this, stated with the estimate: 60%); middle value at least 5.0-fold (0.69 log units) from the limit.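

In this assay compound 3 reads > 10 mg/kg as a limit. Compound 4 reads > 100 mg/kg as a limit too. For the compounds shown here, with only these two limits, no step from compound 3 to compound 4 can be read. The compounds shown leave open how dimethylamino and pyrrolidin-1-yl compare at this place on this read-out.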